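Chloro to Methyl on a Shared Core

A few compounds are considered here, and "the series" means these few. Any claim that something is new, unique, unknown or untested is made for them only; others in the source may bear on it.

Compound 1 `O=c1c(-c2nn[nH]n2)c[nH]c2ccccc12`: > 20 mg/kg
Compound 2 `O=c1c(-c2nn[nH]n2)c[nH]c2ccc(Cl)cc12`: > 25 mg/kg

In a functional assay on the whole organism (strain Sprague-Dawley) for inhibition, with Rattus norvegicus as the target (a lower number here means that less compound is needed, a higher number that more compound is needed for the effect), compound 1 gives > 20 mg/kg, a limit of the assay rather than a number; it sits at the limit of > 20 mg/kg in this assay, at which 1 of the 2 values shown sits. Compound 2 gives > 25 mg/kg in this assay, again only a limit, and stands at the limit of > 25 mg/kg in this assay, at which 1 of the 2 values shown sits. The step that the two limits leave unreadable from compound 1 to compound 2 therefore cannot be read. Compound 3 `Cc1ccc2[nH]cc(-c3nn[nH]n3)c(=O)c2c1` differs from compound 2 by methyl in place of chloro on an aromatic carbon. With no readable step to build on, no change beyond the scatter is expected in this assay. Compound 3 is expected to give 30 mg/kg, with a range from 10 mg/kg to 100 mg/kg. The estimated step that the limit leaves unreadable from compound 2 to compound 3 is expected to lie within the scatter, and a further limit is likely.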

Compound 3, minimum effective dose: > 25 mg/kg
Compound 3 gave a limit, no number (the forecaster's own chance of this, stated with the estimate: 75%); the middle value lies beyond the limit too.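

In this assay compound 3 gives > 25 mg/kg, a limit of the assay. Among the compounds shown here, no step among compound 1, compound 2 and compound 3 can be read. The compounds shown leave open what dose of any of them gives the effect.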